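Methyl for methoxy on the aryl piperazine succinimide amides

A few compounds are considered here, and "the series" means these few. Any claim that something is new, unique, unknown or untested is made for them only; others in the source may bear on it.

In a functional assay on the whole organism (strain Swiss) with Mus musculus as the target, in the maximal electroshock model, with a stated time of 0.5 h, at a dose of 300 mg/kg by the intraperitoneal route (a lower number here means a weaker effect, a higher number a stronger effect of the compound at the dose given), compound 1 `COc1cccc(N2CCN(C(=O)C(C)N3C(=O)CCC3=O)CC2)c1` gives 50%. In this assay compound 2 `CCC(C(=O)N1CCN(c2cccc(Cl)c2)CC1)N1C(=O)CCC1=O` gives 50%, so compound 1 stands level with compound 2 at the digits given, within the scatter. Compound 3 `Cc1cccc(N2CCN(C(=O)C(C)N3C(=O)CCC3=O)CC2)c1` differs from compound 1 by methyl in place of methoxy on an aromatic carbon. Going by the values given here, no pair of measured compounds carries this change, and compound 2 carries an unrelated difference. The expected step in this assay is no change at the digits printed from compound 1 to compound 3 (within the scatter), none beyond the scatter in either direction. Compound 3 is therefore estimated at 50%, within 30% to 70%.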

Compound 3, a percentage reported as activity, at one dose (the size of the read-out at that dose, not a potency): 50%
Compound 3: the middle estimate sits on the measured number at the digits printed, within the range that was stated.
By their numbers in this assay, from the lowest: compounds 1, 2 and 3 (each within the scatter of the next).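

In this assay, going by these compounds alone, the change from 3-methoxyphenyl to 3-methylphenyl gives no change at the digits printed from compound 1 to compound 3 (within the scatter) and is the first reading of a single change at this place on the aromatic ring. At this one dose, the read-out therefore tolerates methyl in place of methoxy, a swap that removes one hydrogen-bond acceptor. Nothing on hand explains this result. From the compounds shown here alone, whether an amine, a carboxylic acid or a longer chain at this place would shift the read-out remains open. Also open, going by these compounds, is whether methyl and methoxy stay level at other doses.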